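The source may hold more compounds than are shown below. What is called first, only, known or untested is meant among the compounds shown, and "the series" means these compounds.

Measured compounds:
compound 1, `C=CC1=C(C(=O)NCc2ccc(C)cc2)C(c2ccc(F)cc2)OC1`, in a functional assay on HeLa cells (Homo sapiens) for cytotoxicity, read by MTT assay, with a stated time of 24 h; a lower number here means a stronger inhibitor, a higher number a weaker inhibitor: > 100000 nM
compound 2, `C=CC1=C(C(=O)NCCCCC)C(c2ccc(Cl)c(Cl)c2)OC1`, in this assay: > 100000 nM

Compound 1 has the structure `C=CC1=C(C(=O)NCc2ccc(C)cc2)C(c2ccc(F)cc2)OC1`. In this assay compound 1 gives > 100000 nM, and this is a limit of the assay rather than a number. Compound 2, `C=CC1=C(C(=O)NCCCCC)C(c2ccc(Cl)c(Cl)c2)OC1`, gives in this assay > 100000 nM, again a limit and not a number. Both measured values sit at the limit of > 100000 nM in this assay, at which 2 of the 2 values shown sit, so compound 1 cannot be placed above or below compound 2 on the numbers shown, and no step between two measured numbers exists.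

Compound 3, `C=CC1=C(C(=O)NCCCCC)C(c2ccc(F)cc2)OC1`, has not yet been measured. Compared with compound 1 it carries butyl in place of 4-methylphenyl on a saturated chain carbon bound to an amide-type nitrogen. Compound 2 already carries the pentyl chain on the amide, so the new compound sits between two measured compounds that both end at the limit. In this assay no step beyond the scatter is expected for compound 3; the open question is only whether a number appears at all.

Compound 3 is expected to give 100000 nM, with a range from 30000 nM to 300000 nM. This estimate means an expected step of a number no higher from compound 1 to compound 3 (the limit leaves the size open), within the scatter.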

Compound 3, half-maximal inhibitory concentration: > 100000 nM
Compound 3 gave a limit, no number; the forecaster's own chance of this, stated with the estimate: 85%; the middle value sits exactly at the limit.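

In this assay compound 3 gives > 100000 nM, which is a limit and not a number. No step can be read between compound 1 and compound 3, and all the compounds end at the same limit: the limit of > 100000 nM in this assay, at which 3 of the 3 values shown sit.

The compounds shown leave open whether pentyl in place of 4-methylbenzyl changes the result at all, as none gives a number to compare.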